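The source may hold more compounds than are shown below. What is called first, only, known or untested is meant among the compounds shown, and "the series" means these compounds.

Measured in an ADME assay on MDCK-II cells (Canis lupus familiaris) for permeability; on this read-out lower numbers stand for lower permeability and higher numbers for higher permeability:
Compound 1 `Cc1cnc(-c2cc(Oc3ccc(S(C)(=O)=O)cc3)cc(OC(C)C)c2)[nH]c1=O`: 17 10^-6 cm/s
Compound 2 `Cc1cc(=O)[nH]c(-c2cc(Oc3ccc(S(C)(=O)=O)cc3)cc(OC(C)C)c2)n1`: 4.8 10^-6 cm/s
Compound 3 `CC(C)Oc1cc(Oc2ccc(S(C)(=O)=O)cc2)cc(-c2ncc(C(C)C)c(=O)[nH]2)c1`: "not determined" (no result reported)

Compound 3 has no number in this assay, so it offers no starting value. Compound 4 `COc1cnc(-c2cc(Oc3ccc(S(C)(=O)=O)cc3)cc(OC(C)C)c2)[nH]c1=O` has methoxy in place of isopropyl on an aromatic carbon. Going by the values given here, no measured step covers this exchange. Among the compounds with values here, the only step available, a 3.5-fold lower number from compound 1 to compound 2 (0.55 log units; beyond the scatter), is modest but beyond the scatter, and it shows only that a change on this ring can move the read-out. No size or direction can therefore be expected for a step from compound 3. The estimate rests instead on the range set by compound 2 at 4.8 10^-6 cm/s and compound 1 at 17 10^-6 cm/s, leaning towards the higher value. For compound 4, the expected value in this assay is 12 10^-6 cm/s, with an estimated range of 5 10^-6 cm/s to 26 10^-6 cm/s.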

Compound 4, apparent permeability: 3.9 10^-6 cm/s
Compound 4: middle estimate off by 3.1-fold (0.49 log units), on the high side; the whole stated range lies above it.
By their numbers in this assay, from the lowest: compounds 4 and 2 (each within the scatter of the next); then compound 1.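

In this assay, methoxy in place of methyl on this aromatic carbon gives a 4.4-fold lower number from compound 1 to compound 4 (0.64 log units; beyond the scatter), so the read-out responds to this exchange at this position by more than the scatter. The second comparison gives a 1.2-fold lower number from compound 2 to compound 4 (0.09 log units; within the scatter), which shows that a methoxy group here leaves compound 4 within the scatter of compound 2, whose change lies elsewhere on the same ring.

The step from compound 3 cannot be read, and nothing given here accounts for these numbers. From the compounds shown here alone, how an amine or a longer chain such as ethoxy on this carbon would read remains open.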